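The compounds below may be only part of what the source reports. "The series", "measured", "known", "first", "only" and "open" are said of these compounds alone.

Of the compounds shown here, two that share a core have been measured for their ability to slow the growth of a human cancer cell line. Compound 1 `O=C1CS/C(=N/Nc2nncc3ccccc23)N1c1ccccc1` gives 44 nM in a functional assay on MDA-MB-435 cells (Homo sapiens) for antiproliferative activity, read by sulforhodamine B assay, with a stated time of 72 h; a higher number here means a weaker inhibitor, a lower number a stronger inhibitor. Compound 2 `O=S(=O)(Nc1ccccn1)c1ccc(Nc2nncc3ccccc23)cc1`, which carries a sulfonamide on a phenyl ring, gives 36 nM in this assay; this value sits alongside that of compound 1, the two numbers lying within the usual scatter of each other, so neither compound can be called the stronger.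

The next compound, compound 3 `NS(=O)(=O)c1ccc(Nc2nncc3ccccc23)cc1`, is compound 2 with one change: hydrogen in place of pyridin-2-yl on a sulfonamide nitrogen. Within the data shown here, no pair of measured compounds shows what this kind of change does, so the expectation rests on compound 2 alone. A small step is expected, from compound 2 to compound 3 a 2.2-fold higher number from compound 2 to compound 3 (0.35 log units; beyond the scatter) in this assay, if anything toward a weaker inhibitor, and possibly none beyond the scatter. Compound 3 is therefore estimated at 80 nM in this assay, within a range from 25 nM to 300 nM.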

Compound 3, half-maximal inhibitory concentration: 18 nM
Beside the measured number, compound 3's estimate is 4.4-fold (0.65 log units) above it, outside the stated range (below it).
By their numbers in this assay, from the lowest: compounds 3, 2 and 1 (each within the scatter of the next, the first and the last beyond it).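

Putting hydrogen in place of pyridin-2-yl on the sulfonamide nitrogen gives a 2.0-fold lower number from compound 2 to compound 3 (0.30 log units; within the scatter) in this assay. In this one pair, then, the entire aromatic ring can be removed from this nitrogen without a difference that stands clear of the usual scatter. The plain sulfonamide of compound 3 thus belongs in the same range as compound 2, and no measurement available here accounts for this outcome.

The compounds shown leave open how other groups on this nitrogen would compare, such as a methyl, an acetyl or a phenyl, which would fill the gap between hydrogen and pyridin-2-yl. They also leave open whether the same change would give a similarly small step on a different cancer cell line.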